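Adding one more methoxy to compound 3

This account rests on a few compounds, and the source may have more. Where it says the series, first, only, none or still open, it means among the compounds named here.

In a functional assay on HT-1080 cells (Homo sapiens) for cytotoxicity, read by MTT assay, with a stated time of 72 h (on this read-out higher numbers stand for weaker inhibition and lower numbers for stronger inhibition), compound 1 `COc1cccc(/C=C2\CCC/C(=C\c3ccc(OC)c(OC)c3)C2=O)c1` gives 4600 nM and compound 2 `COc1ccc(/C=C2\CCC/C(=C\c3ccc(OC)c(OC)c3)C2=O)cc1` gives 7200 nM while compound 3 `COc1ccc(/C=C2\CCC/C(=C\c3ccc(OC)c(OC)c3)C2=O)cc1OC` gives 3000 nM as its number. Compound 3 is separated by more than the scatter from compound 2 only. Both steps into compound 3 put methoxy in place of hydrogen on an aromatic carbon: a 2.4-fold lower number from compound 2 to compound 3 (0.38 log units; beyond the scatter) is modest and a 1.5-fold lower number from compound 1 to compound 3 (0.19 log units; within the scatter) is not a real difference. Compound 4 `COc1ccc(/C=C2\CCC/C(=C\c3cc(OC)c(OC)c(OC)c3)C2=O)cc1OC` carries one further such change, (methoxy in place of hydrogen on an aromatic carbon), with methoxy in place of hydrogen on an aromatic carbon, ortho to a methoxy group. Going by those two steps, a small drop or none beyond the scatter is expected in this assay for this addition. The estimated move is a 1.2-fold lower number from compound 3 to compound 4 (0.08 log units; within the scatter) and no larger. Compound 4 is estimated at 2500 nM with an expected range from 1000 nM to 6000 nM.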

Compound 4, half-maximal inhibitory concentration: 1100 nM
The estimate for compound 4 lay 2.3-fold (0.36 log units) above the measured number, within the range that was stated.
By their numbers in this assay, from the lowest: compound 4; then compounds 3, 1 and 2 (each within the scatter of the next, the first and the last beyond it).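

In this assay, methoxy in place of hydrogen on this aromatic carbon, ortho to a methoxy group, gives a 2.7-fold lower number from compound 3 to compound 4 (0.44 log units; beyond the scatter), a modest but real change. The same kind of swap at another place on the core gave a 1.5-fold lower number from compound 1 to compound 3 (0.19 log units; within the scatter), so the place of the added methoxy can matter here. Nothing available explains this drop. The compounds shown leave open whether methoxy itself is needed at this position, or whether a hydroxy group, a chlorine atom or a longer ethoxy chain would give a similar number.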